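Removing a Nitro Group Across Two Related Cores

A few compounds are considered here, and "the series" means these few. Any claim that something is new, unique, unknown or untested is made for them only; others in the source may bear on it.

Measured compounds:
compound 1 `CCOc1ccc2nc(Cl)c(/C=N/NC(=O)c3cc4cc([N+](=O)[O-])ccc4oc3=O)cc2c1`: 15700 nM
compound 2 `CCOc1ccc2nc(Cl)c(/C=N/NC(=O)c3cc4ccccc4oc3=O)cc2c1`: 6320 nM
compound 3 `O=C(N/N=C/c1ccncc1)c1cc2cc([N+](=O)[O-])ccc2oc1=O`: 13000 nM

Of the compounds shown here, three have been measured in a functional assay on CCRF-CEM cells (Homo sapiens) for antiproliferative activity, read by fluorescence and resazurin assay, with a stated time of 48 h; on this read-out higher numbers stand for weaker inhibition and lower numbers for stronger inhibition. Compound 1 gives 15700 nM, compound 2 gives 6320 nM, and compound 3 gives 13000 nM. The values of compound 3 and compound 1 lie within the scatter of each other, while compound 2 stands beyond it. From compound 1 to compound 2 the change is hydrogen in place of nitro on an aromatic carbon, and it gave a 2.5-fold lower number from compound 1 to compound 2 (0.40 log units; beyond the scatter).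

Compound 4 `O=C(N/N=C/c1ccncc1)c1cc2ccccc2oc1=O` has not yet been measured. It differs from compound 3 by hydrogen in place of nitro on an aromatic carbon, the same change, at the same place, as between compound 1 and compound 2. For the measured compounds named here, the difference between the core of compound 1 and the core of compound 3 is not broken down here, so the only guide is that single measured step.

The expected step is a 2.5-fold lower number from compound 3 to compound 4 (0.40 log units; beyond the scatter), resting on the measured step of a 2.5-fold lower number from compound 1 to compound 2 (0.40 log units; beyond the scatter). On that basis compound 4 is estimated at 5200 nM, with an expected range from 2500 nM to 12000 nM.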

Compound 4, half-maximal inhibitory concentration: 3110 nM
Beside the measured number, compound 4's estimate is 1.7-fold (0.22 log units) above it, and the stated range covers the measured number.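

In this assay, putting hydrogen in place of nitro on the second core gave a 4.2-fold lower number from compound 3 to compound 4 (0.62 log units; beyond the scatter), so the change lowered the number on both cores shown. The size of the step carried over from one core to the other as well, with the gap between the two steps no larger than repeated measurements would produce: the same change on two cores in this assay, a 2.5-fold lower number (0.40 log units; beyond the scatter) from compound 1 to compound 2 and a 4.2-fold lower number (0.62 log units; beyond the scatter) from compound 3 to compound 4, 1.7-fold (0.23 log units) apart, within the scatter of two such steps. This shows that, for these two pairs, the step measured on one core was a fair guide to the step on the other, but two pairs do not establish a rule for the series, and they do not show why removing nitro lowers the number.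

The compounds shown leave open what other groups on that aromatic carbon would do, for example an amine, a methoxy group or a chlorine, since only nitro and hydrogen appear there. They also leave open whether the step would hold on a core other than these two.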